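From a Furan Tail to a Phenol Tail on Compound 1

This account rests on a few compounds, and the source may have more. Where it says the series, first, only, none or still open, it means among the compounds named here.

Compound 1 `COc1ccccc1Oc1ccc2c(NCCCNCc3ccco3)ccnc2c1` stands highest of the three numbers measured in an ADME assay for permeability, using PAMPA, with a stated time of 30 min, at pH 7.4 (on this read-out lower numbers stand for lower permeability and higher numbers for higher permeability), giving 317 10^-6 cm/s. Compound 3 `COc1ccc(-c2ccc3c(NCCCNCc4ccco4)ccnc3c2)cc1` gives 237 10^-6 cm/s, and a 1.3-fold lower number from compound 1 to compound 3 (0.13 log units; within the scatter). Compound 2 `Fc1ccc(Cc2ccc3c(NCCCNCc4ccco4)ccnc3c2)c(Cl)c1` gives 23 10^-6 cm/s, and a 14-fold lower number from compound 1 to compound 2 (1.14 log units; beyond the scatter). Compound 4 `COc1ccccc1Oc1ccc2c(NCCCNCc3cccc(OC)c3O)ccnc2c1` differs from compound 1 at a different spot: 2-hydroxy-3-methoxyphenyl in place of furan-2-yl on a saturated chain carbon bound to an amine nitrogen. Among the compounds with values here, none of the measured steps touches this spot; all of them, including a 10-fold higher number from compound 2 to compound 3 (1.01 log units; beyond the scatter), swap the group on the aromatic carbon, and they range from no step beyond the scatter to a large one. For compound 4 the expected step is therefore uncertain, a 2.1-fold lower number from compound 1 to compound 4 (0.32 log units; beyond the scatter), with a lower number expected. The estimate for compound 4 is 150 10^-6 cm/s, in a range from 50 10^-6 cm/s to 400 10^-6 cm/s.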

Compound 4, apparent permeability: 317 10^-6 cm/s
Compound 4: middle estimate off by 2.1-fold (0.32 log units), on the low side, and the stated range covers the measured number.
By their numbers in this assay, from the lowest: compound 2; then compounds 3, 1 and 4 (each within the scatter of the next).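

In this assay, swapping in 2-hydroxy-3-methoxyphenyl for furan-2-yl on a saturated chain carbon bound to an amine nitrogen gives no change at the digits printed from compound 1 to compound 4 (within the scatter). Within the data shown here, this is the first look at this position, and it shows that a bigger aromatic ring carrying a hydrogen-bond donor can enter here with no step beyond the scatter. Nothing available explains why the number holds. From the compounds shown here alone, an amine or a carboxylic acid at this place remains open. So does whether 2-hydroxy-3-methoxyphenyl gives the same result alongside 2-chloro-4-fluorobenzyl on the aromatic carbon.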